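A few compounds are considered here, and "the series" means these few. Any claim that something is new, unique, unknown or untested is made for them only; others in the source may bear on it.

Measured in a functional assay on HepG2 cells (Homo sapiens) for inhibition, read by CCK-8 assay, with a stated time of 48 h; a higher number here means a weaker inhibitor, a lower number a stronger inhibitor:

- compound 1 `Cc1ccc(C2=NN(C3=NC(c4ccccc4)CS3)C(c3ccc4ccccc4c3)C2)cc1`: 14700 nM
- compound 2 `COc1ccc(C2=NN(C3=NC(c4ccccc4)CS3)C(c3ccc4ccccc4c3)C2)cc1`: 12600 nM
- compound 3 `Brc1ccc(C2=NN(C3=NC(c4ccccc4)CS3)C(c3ccc4ccccc4c3)C2)cc1`: 20300 nM

Compound 3 carries the highest of the three numbers, but neither neighbour is separated from it by more than the scatter: a 1.4-fold higher number from compound 1 to compound 3 (0.14 log units; within the scatter) and a 1.6-fold higher number from compound 2 to compound 3 (0.21 log units; within the scatter). The three measured compounds share one core and differ only in the group on the carbon with a double bond to nitrogen; the swap of methyl for methoxy there, a 1.2-fold lower number from compound 1 to compound 2 (0.07 log units; within the scatter), is likewise within the scatter. For the measured compounds named here, on the numbers so far, the substituent on this phenyl ring has not moved the read-out of this assay beyond its noise.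

Compound 4 `Cc1ccc(C2=NN(C3=NC(c4ccccc4)CS3)C(c3ccc4ccccc4c3)C2)cc1C` is the next step from compound 3: 3,4-dimethylphenyl in place of 4-bromophenyl on a carbon with a double bond to nitrogen. Two of the measured steps bear on it. Going by the values given here, the bromo-to-methyl exchange is covered by compound 1 against compound 3, within the scatter; the additional methyl of the 3,4-dimethylphenyl group has no measured counterpart, so its contribution is unknown. With all three measured exchanges at this position inside the scatter, no step beyond the scatter is expected from compound 3 to compound 4, a 1.5-fold lower number from compound 3 to compound 4 (0.16 log units; within the scatter), and the number should sit close to that of compound 1. Compound 4 is therefore estimated at 14000 nM in this assay, with a range from 7000 nM to 28000 nM.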

Compound 4, half-maximal inhibitory concentration: 7370 nM
Beside the measured number, compound 4's estimate is 1.9-fold (0.28 log units) above it, and the stated range covers the measured number.
By their numbers in this assay, from the lowest: compounds 4, 2, 1 and 3 (each within the scatter of the next, the first and the last beyond it).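

In this assay, 3,4-dimethylphenyl in place of 4-bromophenyl gives the first step at this position to lie beyond the scatter, a 2.8-fold lower number from compound 3 to compound 4 (0.44 log units; beyond the scatter), so the group on this carbon can move the read-out, though only modestly on the numbers shown. This separation holds only against compound 3: the step of a 1.7-fold lower number from compound 2 to compound 4 (0.23 log units; within the scatter) stays within the scatter, as does the step of a 2.0-fold lower number from compound 1 to compound 4 (0.30 log units; within the scatter), which is the added methyl alone, so that methyl cannot be separated from the noise on its own, and compound 4 is distinct only from the bromo compound. Nothing measured accounts for this difference between the 4-bromophenyl and 3,4-dimethylphenyl groups.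

The phenyl substituents shown are limited to methyl, methoxy and bromo, so it remains open whether an amine, a carboxylic acid or a longer chain such as butyl on this ring would give a larger step. All four compounds also keep the naphthalen-2-yl group and the rest of the shared core, leaving open how replacing that group would compare with the changes at this position.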